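The compounds below may be only part of what the source reports. "The series", "measured", "known", "first", "only" and "open" are said of these compounds alone.

Three compounds share one core, and each was tested in an ADME assay on HepG2 cells (Homo sapiens) for cytotoxicity, in the presence of a further agent that is not named here; a lower number here means a stronger inhibitor, a higher number a weaker inhibitor. Compound 1 `COc1nc(C(C)c2ccccc2C(F)(F)F)nc(C(=O)NCc2ccccc2)c1O` gives in this assay a value of > 100000 nM, which is a limit of the assay rather than a number. Compound 2 `CN(Cc1ccccc1)C(=O)c1nc(Cc2ccccc2C(F)(F)F)n(C)c(=O)c1O` gives > 100000 nM in this assay, again a limit. Compound 3 `Cn1c(Cc2ccccc2C(F)(F)F)nc(C(=O)CCc2ccccc2)c(O)c1=O` likewise reaches only a limit in this assay, at > 100000 nM. Among the measured compounds shown here, the one step between measured compounds that differ in a single place, a step that the two limits leave unreadable from compound 2 to compound 3, cannot be read in size, since both of its ends are limits; all three values sit at the same limit (the limit of > 100000 nM in this assay, at which 3 of the 3 values shown sit).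

Compound 4 `Cn1c(Cc2ccccc2C(F)(F)F)nc(C(=O)NCc2ccccc2)c(O)c1=O` has not yet been measured; it differs from compound 3 by benzylamino in place of phenethyl on a carbonyl carbon. For the measured compounds named here, no measured step bears on this change directly, and the measured compounds give no readable size of any step in this assay, so no step beyond the scatter is expected in this assay. Compound 4 is expected to give 150000 nM, with a range from 70000 nM to 400000 nM, most probably reported again only as a limit. The expected step that the limit leaves unreadable from compound 3 to compound 4 is estimated to be small.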

Compound 4, half-maximal inhibitory concentration: > 100000 nM
Compound 4: a limit, no number; the forecaster's own chance of this, stated with the estimate: 90%; the middle value lies beyond the limit too.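

Compound 4 also reaches only a limit in this assay, so its steps from compound 2 and from compound 3 cannot be read in size: the limit of > 100000 nM in this assay, at which 4 of the 4 values shown sit. The compounds shown leave open how far past this limit each one lies, and whether any change to the shared core would give a readable number.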